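A Smaller Sulfur Group Replaces the Hydroxyethylsulfonyl

A few compounds are considered here, and "the series" means these few. Any claim that something is new, unique, unknown or untested is made for them only; others in the source may bear on it.

The study measures a physicochemical assay for solubility, at pH 6.5; on this read-out lower numbers stand for lower solubility and higher numbers for higher solubility. Compound 1 `CS(=O)(=O)c1cncc(-c2ccc3ncc(-c4ccc(S(=O)(=O)C5CC5)cc4)n3n2)c1` and compound 3 `CS(=O)(=O)c1ccc(-c2cnc3ccc(-c4ccnc(C(F)(F)F)c4)nn23)cc1` give only a limit of the assay and no number. For compound 1 this assay reports < 5000 nM. For compound 3 this assay reports < 5000 nM. For the measured compounds named here, compound 2 `CS(=O)(=O)c1ccc(-c2cnc3ccc(-c4cccc(S(=O)(=O)CCO)c4)nn23)cc1` is the only compound with a number: in this assay compound 2 gives 8600 nM. The limit matters here, as the limit of < 5000 nM in this assay, at which 2 of the 3 values shown sit, shows, so the range of the measured set is known only from above.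

The step followed is from compound 2 to compound 4 `C[S+]([O-])c1cccc(-c2ccc3ncc(-c4ccc(S(C)(=O)=O)cc4)n3n2)c1`, not yet measured in this assay. The change is a group of 3 heavy atoms (1 carbon, 1 oxygen, 1 sulfur; no ring) in place of a group of 6 heavy atoms (2 carbon, 3 oxygen, 1 sulfur; no ring), on an aromatic carbon. Going by the values given here, no step between measured compounds is available to guide the size of the effect. The author expects the smaller group to leave compound 4 no more soluble than compound 2, with a step from compound 2 to compound 4 of a 1.7-fold lower number from compound 2 to compound 4 (0.24 log units; within the scatter) that may reach beyond the usual scatter toward lower solubility. Compound 4 is estimated at 5000 nM, with a range from 1500 nM to 15000 nM.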

Compound 4, solubility: 157000 nM
For compound 4 the middle estimate is 31-fold (1.50 log units) below the measured one; the measured number lies above the stated range.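

The exchange gives an 18-fold higher number from compound 2 to compound 4 (1.26 log units; beyond the scatter), so the group on this aromatic carbon can move the read-out of this assay well beyond the scatter. The higher number comes with the smaller group, which counts 0 hydrogen-bond donors and 1 hydrogen-bond acceptor against 1 and 3 in the (2-hydroxyethyl)sulfonyl, so in this pair a high read-out does not depend on the (2-hydroxyethyl)sulfonyl. Compound 1 and compound 3 each remain a limit and not a number: the limit of < 5000 nM in this assay, at which 2 of the 4 values shown sit.

This single step does not separate the effect of the shorter group from that of the changed sulfur, and the compounds shown do not tell why the number rose. As far as these compounds go, how an amine, a carboxylic acid or a longer chain on this aromatic carbon would read in this assay also remains open.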